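Bromo to chloro exchange on the phenol of compound 2

A few compounds are considered here, and "the series" means these few. Any claim that something is new, unique, unknown or untested is made for them only; others in the source may bear on it.

Of the compounds shown here, two have numbers so far in an assay for inhibition of Alpha amylase (Homo sapiens), with a stated time of 10 min; a higher number here means a weaker inhibitor, a lower number a stronger inhibitor. Compound 1 `COc1ccc(Br)c(-c2nc3ccccc3[nH]2)c1O` gives 2480 nM. Going by the values given here, compound 2 `Cc1cc2nc(-c3cc(Cl)cc(Br)c3O)[nH]c2cc1C` gives 2920 nM, the higher of the two numbers; its only neighbour is compound 1, whose number differs from it by less than the usual scatter, so the two cannot be told apart on these data.

Compound 3 `Cc1cc2nc(-c3cc(Cl)cc(Cl)c3O)[nH]c2cc1C` has not yet been measured in this assay. It differs from compound 2 in one place, chloro in place of bromo on an aromatic carbon: the chloro sits on an aromatic carbon of a six-membered aromatic ring of carbon only, ortho to a hydroxy group and meta to a chloro group. Among the compounds with values here, no measured pair shows this exchange, so there is no step to lean on; the expectation is a step no larger than the scatter, with no direction that can be called. Compound 3 is therefore estimated to give 3500 nM in this assay, with a range from 1500 nM to 8000 nM. The step this estimate implies, from compound 2 to compound 3, is expected to be a 1.2-fold higher number from compound 2 to compound 3 (0.08 log units; within the scatter).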

Compound 3, half-maximal inhibitory concentration: 2980 nM
For compound 3 the middle estimate is 1.2-fold (0.07 log units) above the measured one; measured number inside the range.
By their numbers in this assay, from the lowest: compounds 1, 2 and 3 (each within the scatter of the next).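

At the aromatic carbon ortho to a hydroxy group and meta to a chloro group, chloro in place of bromo gives a 1.0-fold higher number from compound 2 to compound 3 (0.01 log units; within the scatter) in this assay and so leaves the two halogens indistinguishable at this position on this core. Going by these compounds alone, this is the first step between compounds that differ in one place, and it gives a direct reading for one position that the comparison of compound 1 with compound 2 could not give, as those two differ in more than one place. No measured property of these compounds accompanies the result, and the data offer no explanation for it.

As far as these compounds go, whether this position tolerates anything other than a halogen stays open: fluoro, a methoxy group, an amine or a carboxylic acid on the same carbon would test that in this assay, and hydrogen there would show whether a substituent is needed at all. Within the data shown here, whether chloro and bromo also read alike on the core of compound 1 is open too, as this single pair is the only one that shows the exchange.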